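Sulfonyl to sulfanyl swap on the compound 1 core

The compounds below may be only part of what the source reports. "The series", "measured", "known", "first", "only" and "open" are said of these compounds alone.

Compound 1 `Cc1ccc(S(=O)(=O)/C(=C/c2ccccc2OCc2ccccc2)C(=O)c2ccc(Br)cc2)cc1` is assessed in a functional assay on DU-145 cells (Homo sapiens) for inhibition, read by trypan blue exclusion, with a stated time of 96 h (on this read-out lower numbers stand for stronger inhibition of growth and higher numbers for weaker inhibition of growth), where compound 1 gives 1000 nM. Compound 2 `COc1ccccc1/C=C(\C(=O)c1ccc(Br)cc1)S(=O)(=O)c1ccc(C)cc1` gives 1000 nM and compound 3 `O=C(/C(=C\c1ccc(OCc2ccccc2)cc1)S(=O)(=O)Cc1ccc(Cl)cc1)c1ccc(Cl)cc1` gives 1000 nM, so compound 1 stands level with both at the digits shown, within the scatter of the method. Within the data shown here, the one measured single-place step, no change at the digits printed from compound 1 to compound 2 (within the scatter), shows that this change left the read-out unmoved.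

Compound 4 `O=C(/C(=C\c1ccccc1OCc1ccccc1)SCc1ccc(F)cc1)c1ccc(Br)cc1` is the next entry, differing from compound 1 as follows: (4-fluorobenzyl)sulfanyl in place of (4-methylphenyl)sulfonyl on a double-bonded chain carbon bound to a carbonyl carbon and a double-bonded chain carbon. Among the measured compounds shown here, no measured step touches this position, and compound 3 is not joined to compound 1 by a single-place step, so its value can only be read as a further example of the same level across the series. With nothing in the measured steps pointing in either direction, no movement beyond the scatter is expected; the step from compound 1 to compound 4 is estimated as no change at the digits printed from compound 1 to compound 4 (within the scatter). For compound 4 the estimated value in this assay is 1000 nM, with an expected range from 300 nM to 3000 nM.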

Compound 4, concentration for 50% growth inhibition: 1000 nM
Compound 4: middle estimate and measured number agree at the digits printed, within the range that was stated.
By their numbers in this assay, from the lowest: compounds 1, 2, 3 and 4 (each within the scatter of the next).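

Among these compounds, the exchange of (4-methylphenyl)sulfonyl for (4-fluorobenzyl)sulfanyl on a double-bonded chain carbon bound to a carbonyl carbon and a double-bonded chain carbon gives no change at the digits printed from compound 1 to compound 4 (within the scatter) in this assay, the first reading at this place on the core of compound 1. The read-out therefore holds level through a change that removes the 2 double bonds outside aromatic rings carried by the leaving group and takes the group's hydrogen-bond acceptors from 2 to 1, while an aromatic ring of carbon only remains in both groups.

Going by these compounds, the sulfur state and the ring substituent change together in this one step, so their separate contributions stay open. On these data alone, how an amine or a carboxylic acid at this place would read is also open.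

Nothing on hand explains why the value holds level at this place.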